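From Chloro to Bromo on the Benzyl Ring

A few compounds are considered here, and "the series" means these few. Any claim that something is new, unique, unknown or untested is made for them only; others in the source may bear on it.

Measured so far in a functional assay on A2780 cells (Homo sapiens) for antiproliferative activity, read by resazurin assay, with a stated time of 72 h; a higher number here means a weaker inhibitor, a lower number a stronger inhibitor:
- compound 1 `CN(Cc1ccccc1F)C(=O)c1cc2c(Cc3ccccc3)n[nH]c2cc1O`: 1500 nM
- compound 2 `CN(Cc1ccccc1Cl)C(=O)c1cc2c(Cc3ccccc3)n[nH]c2cc1O`: 1100 nM

With only these two numbers, compound 2 has no clear rank. Compound 2 gives 1100 nM, and compound 1 gives 1500 nM, a gap that lies within the usual scatter of repeated measurements.

The next compound replaces 2-chlorobenzyl with 2-bromobenzyl, giving compound 3 `CN(Cc1ccccc1Br)C(=O)c1cc2c(Cc3ccccc3)n[nH]c2cc1O`: bromo in place of chloro on an aromatic carbon. In words, bromo takes the place of chloro on an aromatic carbon, ortho to a large group.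

Among the measured compounds shown here, one measured step bears on this change, chloro in place of fluoro on an aromatic carbon: a 1.4-fold lower number from compound 1 to compound 2 (0.13 log units; within the scatter). That single step is thin evidence, but it stayed within the scatter. A step beyond the scatter is therefore not expected in this assay, in either direction. The estimated step is a 1.1-fold lower number from compound 2 to compound 3 (0.04 log units; within the scatter).

Compound 3 is expected at about 1000 nM.

The expected range runs from 500 nM to 2200 nM.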

Compound 3, half-maximal inhibitory concentration: 1200 nM
For compound 3 the middle estimate is 1.2-fold (0.08 log units) below the measured one; low and high end bracket the measured number.
By their numbers in this assay, from the lowest: compounds 2, 3 and 1 (each within the scatter of the next).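

In this assay, bromo in place of chloro gives a 1.1-fold higher number from compound 2 to compound 3 (0.04 log units; within the scatter) and bromo in place of fluoro gives a 1.3-fold lower number from compound 1 to compound 3 (0.10 log units; within the scatter) and so neither step rises above the usual scatter of repeated measurements. Before compound 3 there was only one pair to compare, but now fluoro, chloro and bromo can all be compared at this same place on the benzyl ring, and all three pairs lie within the scatter, so this assay cannot tell these three halogens apart at this position. Nothing measured here offers a reason for how close the three compounds lie.

On these data alone, all three compounds carry a halogen at this place, so it remains open whether a different kind of group, such as methoxy, an amine or a carboxylic acid, would give a step beyond the scatter, or whether plain hydrogen would do so. Also open, as far as these compounds go, is whether the same closeness would hold with the halogen moved elsewhere on this ring, or with changes to the other benzyl group or to the methyl on the amide nitrogen.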